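This account rests on a few compounds, and the source may have more. Where it says the series, first, only, none or still open, it means among the compounds named here.

Compound 1 `COc1cc(/C(Cl)=C/C=C(\C#N)C(=O)c2c[nH]c3ccccc23)cc(OC)c1OC` — in a functional assay on MCF7 cells (Homo sapiens) for cytotoxicity, read by sulforhodamine B assay, with a stated time of 48 h (a lower number here means that less compound is tolerated, a higher number that more compound is tolerated), compound 1 gives > 100000 nM, which is a limit of the assay rather than a number.
Compound 2 `COc1ccc2[nH]cc(C(=O)/C(C#N)=C/C=C(\Cl)c3ccc(OC)c(OC)c3)c2c1` — in this assay compound 2 gives > 100000 nM, again a limit of the assay and not a number.

Where compound 1 stands is therefore fixed only as a limit. Among the measured compounds shown here, the same holds for the one further value shown, so both measured values sit at the limit of > 100000 nM in this assay, at which 2 of the 2 values shown sit, and no step between measured compounds can be drawn from them; neither compound can be placed above or below the other.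

Compound 3 `COc1cc(/C(Cl)=C/C=C(\C#N)C(=O)c2c[nH]c3ccc(Br)cc23)cc(OC)c1OC` has not yet been measured in this assay. It differs from compound 1 in one place: bromo in place of hydrogen on an aromatic carbon, the change reading one bond further out as 1H-indol-3-yl to 5-bromo-1H-indol-3-yl. For the measured compounds named here, no measured step exists for this change, and no property of the entering bromo is recorded here. With compound 1 at the limit, the expectation is that compound 3 most likely remains at the limit as well, with a step of a number no higher from compound 1 to compound 3 (the limit leaves the size open) expected to be none beyond the scatter. The estimate for compound 3 in this assay is therefore 100000 nM, expected to fall between 30000 nM and 300000 nM.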

Compound 3, concentration lethal to 50% of the cells: > 100000 nM
Compound 3 gave a limit, no number (the forecaster's own chance of this, stated with the estimate: 75%); the middle value sits exactly at the limit.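

Compound 1 and compound 3 both stop at a limit in this assay, so no step can be read between them for bromo in place of hydrogen: the limit of > 100000 nM in this assay, at which 3 of the 3 values shown sit. The compounds shown leave open whether that change alters the concentration tolerated at all, and where any of the three compounds would fall as an actual number.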